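From 1H-pyrazol-4-yl to 1,3-oxazol-4-yl on a carbonyl carbon

A few compounds are considered here, and "the series" means these few. Any claim that something is new, unique, unknown or untested is made for them only; others in the source may bear on it.

- compound 1 `O=C(c1cn[nH]c1)N1CCC(C(=O)N2N=CCC2c2ccccc2)CC1` gives 1.6 L/kg in an ADME assay on the whole organism (Rattus norvegicus) for pharmacokinetics, at a dose of 1 mg/kg by the intravenous route; on this read-out lower numbers stand for narrower distribution and higher numbers for wider distribution into tissues
- compound 2 `Cc1nnc(N2CCC(C(=O)N3N=CC[C@H]3c3cc(F)cc(F)c3)CC2)o1` gives 1.3 L/kg in this assay

Compound 1 at 1.6 L/kg and compound 2 at 1.3 L/kg lie within the usual scatter of each other, so compound 1 does not stand apart. Compound 3 `O=C(c1cocn1)N1CCC(C(=O)N2N=CCC2c2ccccc2)CC1` differs from compound 1 by a single change 1,3-oxazol-4-yl in place of 1H-pyrazol-4-yl on a carbonyl carbon in which 1,3-oxazol-4-yl stands in place of 1H-pyrazol-4-yl on a carbonyl carbon. Going by the values given here, no measured pair shows a single change, so the expectation rests on compound 1 at 1.6 L/kg alone, and in this assay no shift beyond the scatter is expected. The expected 1.1-fold lower number from compound 1 to compound 3 (0.06 log units; within the scatter) is therefore small. Compound 3 is estimated at 1.4 L/kg with 0.8 L/kg to 2.5 L/kg as its expected range.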

Compound 3, volume of distribution at steady state: 0.98 L/kg
Estimate against measurement, compound 3: 1.4-fold (0.15 log units) above; the range from low to high includes it.
By their numbers in this assay, from the lowest: compounds 3, 2 and 1 (each within the scatter of the next).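

Going by these compounds alone, replacing 1H-pyrazol-4-yl with 1,3-oxazol-4-yl on a carbonyl carbon gives a 1.6-fold lower number from compound 1 to compound 3 (0.21 log units; within the scatter) in this assay, the first single-change pair at this position. The group that enters has 0 hydrogen-bond donors and the group that leaves has 1, yet in this one pair that difference brings no shift beyond the scatter. No measurement shown bears on why the two compounds read as they do.

On these data alone, it remains open whether an amine, a carboxylic acid or a longer chain on this carbonyl carbon would also stay within the scatter. One pair cannot show whether this result holds on other cores.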